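The compounds below may be only part of what the source reports. "The series", "measured", "known", "first", "only" and "open" are said of these compounds alone.

In a functional assay on THP-1 cells (Homo sapiens) for cytotoxicity, read by MTT assay, with a stated time of 24 h (a lower number here means a stronger inhibitor, a higher number a weaker inhibitor), compound 1 `CCCCCCCCCCn1cc(Cn2cnc3nc(-c4ccccc4)cc(C(F)(F)F)c3c2=O)nn1` gives 16.9 ug/mL. This is the only finite number shown. For compound 2 `CCc1nc2nc(-c3ccccc3)cc(C(F)(F)F)c2c(=O)n1Cc1cn(CCC(F)(F)C(F)(F)C(F)(F)C(F)(F)C(F)(F)C(F)(F)C(F)(F)C(F)(F)F)nn1` the read-out in this assay is reported only as > 200 ug/mL, which is a limit of the assay rather than a measured number; it sits at the limit of > 200 ug/mL in this assay, at which 1 of the 2 values shown sits. Within the data shown here, compound 2 differs from compound 1 in more than one place, so no single step between them can be drawn, and the two values are simply stated side by side. Compound 3 `CCCCCCCCCCn1cc(Cn2c(CC)nc3nc(-c4ccccc4)cc(C(F)(F)F)c3c2=O)nn1` has not yet been measured; it differs from compound 1 by ethyl in place of hydrogen on an aromatic carbon, an ethyl in place of hydrogen on an aromatic carbon. Among the measured compounds shown here, no measured pair shows this change on its own, so in this assay the step is expected to be small, perhaps a mild weakening that may lie within the scatter of repeats. Compound 3 is therefore expected to give about 25 ug/mL, within a range from 8 ug/mL to 80 ug/mL. The expected step is a 1.5-fold higher number from compound 1 to compound 3 (0.17 log units; within the scatter).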

Compound 3, half-maximal inhibitory concentration: 82.7 ug/mL
For compound 3 the middle estimate is 3.3-fold (0.52 log units) below the measured one; measured number above the stated range.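

The hydrogen on this aromatic carbon, between two ring nitrogen atoms, turns out not to be a silent place for a change: in this assay, ethyl in its stead gives a 4.9-fold higher number from compound 1 to compound 3 (0.69 log units; beyond the scatter). Among these compounds, this is the first step in the set that can be read from a change in one place, and it moves the read-out beyond the scatter towards weaker cytotoxicity. Nothing measured here gives a cause for this step.

As far as these compounds go, with a single group at this carbon there is no trend yet, so whether a methyl, a longer chain such as butyl, or an amine there would move the number further or less remains open. Also open, from the compounds shown here alone, is whether ethyl has the same effect when the long chain of compound 1 is replaced by another group.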